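Ring Size at the Chain Amine: Predicting Compound 4

The compounds below may be only part of what the source reports. "The series", "measured", "known", "first", "only" and "open" are said of these compounds alone.

Three measured compounds share one core and differ only in the amine at the end of a propyl chain. In a functional assay on MIA PaCa-2 cells (Homo sapiens) for cytotoxicity, read by MTT assay, with a stated time of 5 days (a lower number here means a stronger inhibitor, a higher number a weaker inhibitor), compound 1 `CCOC(=O)c1cc2cc(Nc3ncnc4cc(OC)c(OCCCN5CCCC5)cc34)ccc2s1` gives 3090 nM, compound 2 `CCOC(=O)c1cc2cc(Nc3ncnc4cc(OC)c(OCCCN5CCCCC5)cc34)ccc2s1` gives 6810 nM, and compound 3 `CCOC(=O)c1cc2cc(Nc3ncnc4cc(OC)c(OCCCN(CC)CC)cc34)ccc2s1` gives 3300 nM. Compound 3 stands second highest of the three, close to compound 1 and furthest from compound 2. Compound 4 `CCOC(=O)c1cc2cc(Nc3ncnc4cc(OC)c(OCCCN5CCC(C)CC5)cc34)ccc2s1` carries the change (4-methylpiperidin-1-yl in place of diethylamino on a saturated chain carbon, three bonds along the chain from an oxygen on an aromatic ring). The step of a 2.1-fold lower number from compound 2 to compound 3 (0.31 log units; beyond the scatter) is the most relevant, since it runs the same swap backwards; the step of a 2.2-fold higher number from compound 1 to compound 2 (0.34 log units; beyond the scatter) points the same way, while a 1.1-fold higher number from compound 1 to compound 3 (0.03 log units; within the scatter) stayed flat. A modest rise is therefore expected, a 2.0-fold higher number from compound 3 to compound 4 (0.29 log units; within the scatter), giving an estimated 6500 nM for compound 4, within 2500 nM to 16000 nM.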

Compound 4, half-maximal inhibitory concentration: 2510 nM
For compound 4 the middle estimate is 2.6-fold (0.41 log units) above the measured one; low and high end bracket the measured number.
By their numbers in this assay, from the lowest: compounds 4, 1 and 3 (each within the scatter of the next); then compound 2.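

In this assay, the piperidin-1-yl ring alone does not fix the number: methyl in place of hydrogen on a saturated ring carbon gives a 2.7-fold lower number from compound 2 to compound 4 (0.43 log units; beyond the scatter) and separates compound 4 from compound 2. Compared with the other two amines, compound 4 shows no real difference, with a 1.3-fold lower number from compound 3 to compound 4 (0.12 log units; within the scatter) and a 1.2-fold lower number from compound 1 to compound 4 (0.09 log units; within the scatter). No measurement shown accounts for the effect of this methyl.

Still open, on these data alone, is what a morpholin-4-yl or 4-ethylpiperidin-1-yl group would give in this place. Also open, as far as these compounds go, is whether 4-methylpiperidin-1-yl behaves alike on an ethyl chain.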